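The compounds below may be only part of what the source reports. "The series", "measured", "known", "first", "only" and "open" are said of these compounds alone.

The measured compounds:

Compound 1, `CC(=O)Oc1ccc2cc(-c3cccs3)c(=O)oc2c1OC(C)=O`. In a functional assay on isolated protein for antagonist activity at adenosine receptor A2b (Homo sapiens) (on this read-out higher numbers stand for weaker inhibition and lower numbers for stronger inhibition), compound 1 gives > 30000 nM, which is a limit of the assay rather than a number.

Compound 2, `CC(=O)Oc1ccc2cc(-c3ccsc3)c(=O)oc2c1OC(C)=O`. In this assay compound 2 gives > 30000 nM, again only a limit.

Compound 3, `O=c1oc2c(O)cccc2cc1-c1cccs1`. In this assay compound 3 gives > 30000 nM, once more a limit.

From compound 1 to compound 2 the change is thiophen-3-yl in place of thiophen-2-yl on an aromatic carbon. The step this makes is a step that the two limits leave unreadable from compound 1 to compound 2, and it cannot be read because of the limit of > 30000 nM in this assay, at which 3 of the 3 values shown sit. Compound 3 has a different core from compound 1, and the difference between the two cores is not broken down here.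

Compound 4, `O=c1oc2c(O)cccc2cc1-c1ccsc1`, has not yet been measured. It differs from compound 3 by thiophen-3-yl in place of thiophen-2-yl on an aromatic carbon, the same change as from compound 1 to compound 2, made at a place described in the same words. Among the measured compounds shown here, the one measured example of this change gave no readable step because of the limit of > 30000 nM in this assay, at which 3 of the 3 values shown sit.

For compound 4 the expected step is a step that the limit leaves unreadable from compound 3 to compound 4. This expectation rests on compound 3 giving only > 30000 nM in this assay. It also rests on the step that the two limits leave unreadable from compound 1 to compound 2 giving no sign that the change brings activity into the readable range. Compound 4 is therefore estimated at 60000 nM, within a range from 20000 nM to 300000 nM, and most probably the assay will again report only a limit for it.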

Compound 4, inhibition constant: > 30000 nM
Compound 4 ended at the assay's limit; the forecaster's own chance of this, stated with the estimate: 85%; the middle value does not contradict the limit.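

In this assay compound 4 gives > 30000 nM, which is a limit of the assay and not a number. The change from compound 3 to compound 4 therefore yields no readable step, for this reason: the limit of > 30000 nM in this assay, at which 4 of the 4 values shown sit. The compounds shown leave open whether thiophen-3-yl and thiophen-2-yl differ at all on this read-out, and what change to these structures would give a readable value.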